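The source may report more compounds than this note shows. Statements on the series, on what has been measured and on what is new or still open speak of the compounds shown alone.

Working notes on the sulfonyl series. Compound 1 `CC1CCN(c2c(S(=O)(=O)c3ccccc3)cnc3c(F)cccc23)CC1`, compound 2 `Cc1ccc(S(=O)(=O)c2cnc3c(F)cccc3c2N2CCC(C)CC2)cc1F` and compound 3 `CC1CCN(c2c(S(=O)(=O)c3ccc(C#N)cc3)cnc3c(F)cccc23)CC1` share one core and differ only in the group on the sulfonyl sulfur. In an assay on isolated protein for displacement of a labelled ligand from metabotropic glutamate receptor 5 (Homo sapiens), with a stated time of 60 min, tested at 1 uM (on this read-out higher numbers stand for more inhibition at the one concentration tested (going by the name of the read-out) and lower numbers for less inhibition), compound 1 gives 13%, compound 2 gives 93% and compound 3 gives 86%. Compound 3 thus stands second of the three on this read-out, close to compound 2 and far from compound 1. Replacing phenyl on the sulfonyl sulfur raised the read-out strongly with either group tried: a number 80 percentage points higher from compound 1 to compound 2 (beyond the scatter) and a number 73 percentage points higher from compound 1 to compound 3 (beyond the scatter). Between the two substituted phenyl groups the gap is small: a number 7 percentage points lower from compound 2 to compound 3 (within the scatter).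

Compound 4 `CC1CCN(c2c(S(=O)(=O)c3ccc(F)c(Cl)c3)cnc3c(F)cccc23)CC1` is not yet measured. Its change from compound 3 is 3-chloro-4-fluorophenyl in place of 4-cyanophenyl on a sulfonyl sulfur. For the measured compounds named here, the only measured exchange of one substituted phenyl for another on the sulfonyl sulfur, compound 2 to compound 3, stayed within the scatter, and compound 2 already carries 3-fluoro-4-methylphenyl at a high read-out. A step no larger than the scatter is therefore expected, a number 2 percentage points higher from compound 3 to compound 4 (within the scatter), with compound 4 estimated at 88%, in a range from 74% to 97%.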

Compound 4, a percentage reported as inhibition, at one concentration (the size of the read-out at that concentration, not a potency): 95%
Beside the measured number, compound 4's estimate is 7 percentage points below it; the measured number falls inside the stated range.
By their numbers in this assay, from the lowest: compound 1; then compounds 3, 2 and 4 (each within the scatter of the next).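

In this assay, 3-chloro-4-fluorophenyl on the sulfonyl sulfur gives a third substituted phenyl well clear of plain phenyl, a number 82 percentage points higher from compound 1 to compound 4 (beyond the scatter). The exchanges among substituted phenyl groups stay small, a number 9 percentage points higher from compound 3 to compound 4 (within the scatter) and a number 2 percentage points higher from compound 2 to compound 4 (within the scatter), and 3-chloro-4-fluorophenyl counts no hydrogen-bond acceptor where 4-cyanophenyl counts one, so neither the nitrile nor that acceptor is required for a high read-out at this position. No supporting data bear on why these substituted phenyl groups differ so sharply from phenyl.

Open, going by these compounds, is whether the high read-out extends to a ring carrying a carboxylic acid or an amine, or to cyclohexyl in place of the aromatic ring. On these data alone, with compounds 2, 3 and 4 unseparated at one concentration, their relative potency also remains open.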